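A few compounds are considered here, and "the series" means these few. Any claim that something is new, unique, unknown or untested is made for them only; others in the source may bear on it.

Compound 1: `Cc1ccccc1-n1c(Nc2nc(-c3ccccc3)cs2)n[nH]c1=S` — 100 mg/kg
Compound 2: `COc1ccc(-n2c(Nc3nc(-c4ccc(Cl)cc4)cs3)n[nH]c2=S)cc1` — 30 mg/kg
Compound 3: `COc1ccccc1-n1c(Nc2nc(-c3ccc(Cl)cc3)cs2)n[nH]c1=S` — 100 mg/kg

In a functional assay on the whole organism (strain Swiss albino) for inhibition, with Mus musculus as the target, with a stated time of 0.5 h (on this read-out higher numbers stand for an effect only at larger amounts of compound and lower numbers for an effect already at smaller amounts), compound 3 stands level with compound 1, the two together giving the highest numbers of the three, while compound 2 sits lowest: a 3.3-fold higher number from compound 2 to compound 3 (0.52 log units; beyond the scatter). Compound 4 is `Cc1ccccc1-n1c(Nc2nc(-c3ccc(Cl)cc3)cs2)n[nH]c1=S`; it differs from compound 3 by methyl in place of methoxy on an aromatic carbon, on an aromatic carbon ortho to a large group. Going by the values given here, no measured step swaps methoxy for methyl, so no direct precedent exists. Compound 1, which also carries 2-methylphenyl on the aromatic nitrogen, gives 100 mg/kg, the same number as compound 3. Compound 4 is therefore expected to show no change at the digits printed from compound 3 to compound 4 (within the scatter), nothing beyond the scatter. The estimate for compound 4 is 100 mg/kg, with a range from 50 mg/kg to 200 mg/kg.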

Compound 4, minimum effective dose: 100 mg/kg
The estimate for compound 4 equals the measured number at the digits printed; low and high end bracket the measured number.
By their numbers in this assay, from the lowest: compound 2; then compounds 1, 3 and 4 (each within the scatter of the next).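

In this assay, methyl in place of methoxy on an aromatic carbon, ortho to a large group, gives no change at the digits printed from compound 3 to compound 4 (within the scatter) and chloro in place of hydrogen gives no change at the digits printed from compound 1 to compound 4 (within the scatter) so neither change moves the number. 2-Methylphenyl in place of 4-methoxyphenyl on the aromatic nitrogen gives a 3.3-fold higher number from compound 2 to compound 4 (0.52 log units; beyond the scatter) and thus the same gap that 2-methoxyphenyl gave. The compounds shown leave open whether an amine or a hydroxyl on this carbon, or 4-methylphenyl on the nitrogen, would shift the number. Nothing available here gives a reason for these results.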